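A few compounds are considered here, and "the series" means these few. Any claim that something is new, unique, unknown or untested is made for them only; others in the source may bear on it.

Working notes on the series in a functional assay on PC-3 cells (Homo sapiens) for inhibition, read by MTT assay, with a stated time of 48 h; on this read-out lower numbers stand for stronger inhibition and higher numbers for weaker inhibition. Compound 1 `COc1ccc(-n2c(SCc3ccccc3)nnc2-c2cc(OC)c(OC)c(OC)c2)cc1` gives 34100 nM. Compound 3 `COc1ccc(-n2c(SCC(=O)c3ccc(F)cc3)nnc2-c2cc(OC)c(OC)c(OC)c2)cc1` gives 58300 nM, the higher of the two exact numbers on paper, but the gap to compound 1 lies within the scatter. For compound 2 `COc1ccc(C(=O)CSc2nnc(-c3cc(OC)c(OC)c(OC)c3)n2-c2ccc(OC)cc2)cc1` the reading is only a limit, > 60000 nM.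

Compound 4 `COc1ccc(-n2c(SCC(=O)C3CC3)nnc2-c2cc(OC)c(OC)c(OC)c2)cc1` is not yet measured. It carries cyclopropyl in place of 4-fluorophenyl on a carbonyl carbon.

For the measured compounds named here, no measured compound carries cyclopropyl, so no step tests this change directly. The closest evidence is the exchange of the group on the saturated chain carbon bound to sulfur, with a 1.7-fold higher number from compound 1 to compound 3 (0.23 log units; within the scatter) and an at least 1.7-fold higher number from compound 1 to compound 2 (0.24 log units; that floor lies within the scatter). The aromatic exchange gives an at least 1.0-fold lower number from compound 2 to compound 3 (0.01 log units; that floor lies within the scatter). None of these steps leaves the scatter, so no step beyond the scatter is expected here, in either direction. The expected step is a 1.3-fold lower number from compound 3 to compound 4 (0.11 log units; within the scatter). For compound 4 the estimated value is 45000 nM, with an expected range of 20000 nM to 80000 nM.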

Compound 4, half-maximal inhibitory concentration: 37200 nM
Compound 4: the middle estimate sits 1.2-fold (0.08 log units) above what was measured; the range from low to high includes it.
By their numbers in this assay, from the lowest: compounds 1, 4 and 3 (each within the scatter of the next). At a limit, above all of these: compound 2.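

In this assay, for the compounds shown here, cyclopropyl on the carbonyl carbon gives a 1.6-fold lower number from compound 3 to compound 4 (0.20 log units; within the scatter), the first reading at this place for a group that is not an aromatic ring. On the saturated chain carbon bound to a sulfur, the cyclopropylcarbonyl exchange gives a 1.1-fold higher number from compound 1 to compound 4 (0.04 log units; within the scatter), so the read-out does not separate this group from phenyl. Compound 2 carries a limit and not a number, so its step, an at least 1.6-fold lower number from compound 2 to compound 4 (0.20 log units; that floor lies within the scatter), is only a floor resting on that limit: the limit of > 60000 nM in this assay, at which 1 of the 4 values shown sits.

None of the compounds shown moves the read-out beyond the scatter through the group on the carbonyl carbon, so it remains unclear whether this place can affect the read-out at all. Going by these compounds, whether an amine, a carboxylic acid or a longer chain there would give a step beyond the scatter stays open.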